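Swapping the aminophenyl for a difluorophenyl on the carbonyl

The compounds below may be only part of what the source reports. "The series", "measured", "known", "first", "only" and "open" are said of these compounds alone.

Compound 1 `COc1ccc(-c2cc(/C=C/C(=O)c3ccc(N)cc3)[nH]n2)cc1` and compound 2 `COc1cc(-c2cc(/C=C/C(=O)c3ccc(N)cc3)[nH]n2)cc(OC)c1OC` share a core and differ only in the methoxy pattern. In a functional assay on SF-268 cells (Homo sapiens) for cytotoxicity, read by sulforhodamine B assay, with a stated time of 48 h, tested at 1 uM (a higher number here means a weaker effect of the compound at the concentration tested, a lower number a stronger effect), compound 1 gives 78%, and compound 2 gives 81%, so the two values lie within the scatter of each other and neither can be called stronger. Compound 3 `COc1cc(-c2cc(/C=C/C(=O)c3ccc(F)c(F)c3)[nH]n2)cc(OC)c1OC` has not been measured in this assay; it differs from compound 2 by 3,4-difluorophenyl in place of 4-aminophenyl on a carbonyl carbon. With no comparable change among the measured pair, the expected step of a number 3 percentage points higher from compound 2 to compound 3 (within the scatter) is small, leaning if at all toward a weaker effect. Compound 3 is therefore estimated at 84%, within 68% to 100%.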

Compound 3, a percentage reported as activity, at one concentration (the size of the read-out at that concentration, not a potency): 83%
Estimate against measurement, compound 3: 1 percentage points above, and the stated range covers the measured number.
By their numbers in this assay, from the lowest: compounds 1, 2 and 3 (each within the scatter of the next).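

In this assay, for the compounds shown here, the first change at the carbonyl carbon gives a number 2 percentage points higher from compound 2 to compound 3 (within the scatter). At this position, then, 3,4-difluorophenyl in place of 4-aminophenyl, which removes the amine nitrogen and the hydrogen-bond donor and acceptor counted for the 4-aminophenyl group, produces no difference that can be told from scatter. No supporting data bear on why this is so. As far as these compounds go, whether a carboxylic acid or a dimethylamino group on that phenyl ring would give a step beyond the scatter remains open. So does how 3,4-difluorophenyl behaves with the methoxy pattern of compound 1.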